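Methoxy for methyl on the sulfonyl ring: second instance

A few compounds are considered here, and "the series" means these few. Any claim that something is new, unique, unknown or untested is made for them only; others in the source may bear on it.

Measured so far:
compound 1 `COc1cc(-c2nc(-c3ccccc3)[nH]c2-c2ccnc(NCCCNS(=O)(=O)c3ccc(C)cc3)n2)ccc1F`, 2590 nM
compound 2 `COc1ccc(S(=O)(=O)NCCCNc2nccc(-c3[nH]c(-c4ccccc4)nc3-c3ccc(F)c(OC)c3)n2)cc1`, 6130 nM
compound 3 `Cc1ccc(S(=O)(=O)NCCCNc2nccc(-c3[nH]c(-c4ccccc4)nc3-c3ccc(F)c(O)c3)n2)cc1`, 26300 nM

All values come from a functional assay on LOX IMVI cells (Homo sapiens) for cytotoxicity, read by MTT assay, with a stated time of 24 h; a lower number here means a stronger inhibitor, a higher number a weaker inhibitor. Compound 3 shows the highest number of the three; its step from compound 1 is a 10-fold higher number from compound 1 to compound 3 (1.01 log units; beyond the scatter), the change being (hydrogen in place of methyl on an oxygen on an aromatic ring). The change of interest, (methoxy in place of methyl on an aromatic carbon), gave a 2.4-fold higher number from compound 1 to compound 2 (0.37 log units; beyond the scatter) on the core of compound 1.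

Compound 4 `COc1ccc(S(=O)(=O)NCCCNc2nccc(-c3[nH]c(-c4ccccc4)nc3-c3ccc(F)c(O)c3)n2)cc1` is not yet measured. It carries the same change, (methoxy in place of methyl on an aromatic carbon), on the core of compound 3; the two cores differ as told for compound 1 against compound 3. A step of similar size is expected for compound 4, a 2.3-fold higher number from compound 3 to compound 4 (0.36 log units; beyond the scatter), resting on the step from compound 1 to compound 2 in this assay. Compound 4 is therefore estimated at 60000 nM, between 25000 nM and 150000 nM.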

Compound 4, half-maximal inhibitory concentration: 13900 nM
Beside the measured number, compound 4's estimate is 4.3-fold (0.64 log units) above it; the measured number lies below the stated range.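

On the core of compound 3, 4-methoxyphenyl in place of 4-methylphenyl gives a 1.9-fold lower number from compound 3 to compound 4 (0.28 log units; within the scatter), so in this assay the step seen on the core of compound 1 does not carry over: the same change on two cores in this assay, a 2.4-fold higher number (0.37 log units; beyond the scatter) from compound 1 to compound 2 and a 1.9-fold lower number (0.28 log units; within the scatter) from compound 3 to compound 4, 4.5-fold (0.65 log units) apart, beyond the scatter of two such steps

Read the other way, hydrogen in place of methyl on the oxygen gives a 2.3-fold higher number from compound 2 to compound 4 (0.36 log units; beyond the scatter) with 4-methoxyphenyl present, a smaller step than with 4-methylphenyl present: the same change on two cores in this assay, a 10-fold higher number (1.01 log units; beyond the scatter) from compound 1 to compound 3 and a 2.3-fold higher number (0.36 log units; beyond the scatter) from compound 2 to compound 4, 4.5-fold (0.65 log units) apart, beyond the scatter of two such steps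

The two changes are thus not independent across these four compounds, but a single pair on each core gives no reason for this and no rule for other cores.

Open, on these data alone, is whether the same dependence holds for other groups on the sulfonyl ring, such as chloro or an amine. Also open, as far as these compounds go, is whether it survives a longer chain.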